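The source may report more compounds than this note shows. Statements on the series, on what has been measured and on what is new or still open speak of the compounds shown alone.

In a functional assay on A549 cells (Homo sapiens) for inhibition, read by sulforhodamine B assay, with a stated time of 48 h, tested at 50 uM (on this read-out higher numbers stand for more inhibition of growth at the one concentration tested and lower numbers for less inhibition of growth), compound 1 `COc1cc2c(cc1CC=C(C)C)C(=O)C[C@@H](c1ccc(Oc3ccc(F)cc3)cc1)O2` gives 27% and compound 2 `COc1cc2c(cc1CC=C(C)C)C(=O)C[C@@H](c1ccc(Oc3cccc([N+](=O)[O-])c3)cc1)O2` gives 37%. Within the data shown here, these are the only two measured values, and the step between them, a number 10 percentage points higher from compound 1 to compound 2 (within the scatter), leaves compound 2 level with compound 1. Compound 3 `CCCCOc1ccc([C@@H]2CC(=O)c3cc(CC=C(C)C)c(OC)cc3O2)cc1` keeps the shared core of compound 2 but carries butyl in place of 3-nitrophenyl on an oxygen on an aromatic ring. That single measured step bears on this change only loosely, since it swaps one substituted phenyl group for another, whereas here the ring is lost altogether. Among the measured compounds shown here, no measured pair shows such a loss. A small shift is therefore expected in this assay, an estimated a number 7 percentage points lower from compound 2 to compound 3 (within the scatter), with no change beyond the scatter and no firm direction. For compound 3 the estimated value is 30%, with an expected range of 13% to 50%.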

Compound 3, percent growth inhibition at one concentration: 37%
Beside the measured number, compound 3's estimate is 7 percentage points below it, and the stated range covers the measured number.
By their numbers in this assay, from the lowest: compounds 1, 2 and 3 (each within the scatter of the next).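

In this assay, the step of no change at the digits printed from compound 2 to compound 3 (within the scatter) shows something the two phenyl-bearing compounds could not: the whole aromatic ring on this oxygen can go, replaced by butyl with no ring at all, without the number leaving the scatter. The step of a number 10 percentage points higher from compound 1 to compound 3 (within the scatter) reads the same way against 4-fluorophenyl, so 3-nitrophenoxy, 4-fluorophenoxy and butoxy cannot be told apart at this position on this read-out. Nothing at hand explains this result.

Still open, going by these compounds, is whether a longer chain than butyl, or a butyl chain ending in an amine or a carboxylic acid, would move the number beyond the scatter. On these data alone, with all three compounds read at one concentration, it also remains open whether they would differ at other concentrations.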